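A few compounds are considered here, and "the series" means these few. Any claim that something is new, unique, unknown or untested is made for them only; others in the source may bear on it.

The measured compounds and their values:
Compound 1, `Cc1cc(=O)oc2cc(OC(=O)CNc3ccccc3[N+](=O)[O-])ccc12`, gives 21.4% in a functional assay on the whole organism (strain Wistar albino) for inhibition, with Rattus norvegicus as the target, read by paw edema, with stated times of 30 min and 1 h, at a dose of 20 mg/kg by the oral route; a higher number here means more inhibition at the dose given (going by the name of the read-out), a lower number less inhibition.
Compound 2, `Cc1cc(=O)oc2cc(OC(=O)CNc3ccccc3Cl)ccc12`, gives 21.4%.
Compound 3, `Cc1cc(=O)oc2cc(OC(=O)CNc3ccc(Cl)cc3)ccc12`, gives 10.7%.

Going from compound 2 to compound 1, the change is nitro in place of chloro on an aromatic carbon, and the result was no change at the digits printed from compound 2 to compound 1 (within the scatter). The cores of compound 2 and compound 3 differ as follows: 4-chlorophenyl in place of 2-chlorophenyl on an amine nitrogen; this step gave a number 10.7 percentage points lower from compound 2 to compound 3 (beyond the scatter), and compound 3 stands lowest of the three.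

Compound 4, `Cc1cc(=O)oc2cc(OC(=O)CNc3ccc([N+](=O)[O-])cc3)ccc12`, has not been measured. It differs from compound 3 by nitro in place of chloro on an aromatic carbon. Among the compounds with values here, this is the same kind of change as the one from compound 2 to compound 1, but the place is not the same: there the nitro sits ortho to a large group, here para to a large group. For compound 4 a small step is expected, a number 1.3 percentage points higher from compound 3 to compound 4 (within the scatter), because the same kind of change earlier gave no change at the digits printed from compound 2 to compound 1 (within the scatter). Compound 4 is therefore estimated at 12%, with a likely range from 4% to 22%.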

Compound 4, a percentage reported as inhibition, in the whole organism at one dose (the size of the read-out at that dose, not a potency): 12.5%
Compound 4: the middle estimate sits 0.5 percentage points below what was measured; the measured number falls inside the stated range.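

In this assay nitro in place of chloro gave a number 1.8 percentage points higher from compound 3 to compound 4 (within the scatter) on this second core, so the result resembles the one seen earlier. Set side by side, the two steps do not differ: the same change on two cores in this assay, no change at the digits printed (within the scatter) from compound 2 to compound 1 and a number 1.8 percentage points higher (within the scatter) from compound 3 to compound 4, 1.8 percentage points apart, within the scatter of two such steps. This shows that, for these two pairs, one built on the 2-chlorophenyl compound and one on the 4-chlorophenyl compound, the change carried over from one core to the other with no readable effect at this single dose, but it does not show that the same would hold on any other core or at any other dose.

The compounds shown leave open whether other groups on the aromatic ring, such as a methoxy, a trifluoromethyl or a carboxylic acid, would match chloro and nitro in this way. They also leave open what a longer chain between the carbonyl and the amine nitrogen would do to the inhibition of paw edema.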